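Benzoyl Ester Variant and Its Expected Cell Tolerance

This account rests on a few compounds, and the source may have more. Where it says the series, first, only, none or still open, it means among the compounds named here.

The series shares one core, carried in compound 1 `CCC1(Cc2ccccc2)OS(=O)(=O)C=C1OCc1ccc(F)cc1`, and the question is how much of each compound cells tolerate, measured as an ADME assay on HEL cells (Homo sapiens) for cytotoxicity, with a stated time of 3 days; a higher number here means that more compound is tolerated, a lower number that less compound is tolerated. Compound 1 reaches only the limit of this assay, > 50000 nM, so no number is known for it. Two relatives are measured: compound 2 `CCCC1(Cc2ccccc2)OS(=O)(=O)C=C1OCc1ccccc1` gives 200000 nM in this assay, and compound 3 `CCC1(CC)OS(=O)(=O)C=C1OCc1ccccc1` gives 200000 nM. The limit at which compound 1 sits, (the limit of > 50000 nM in this assay, at which 1 of the 3 values shown sits), thus leaves open whether it matches them or lies elsewhere.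

Compound 4 `CCC1(Cc2ccccc2)OS(=O)(=O)C=C1OC(=O)c1ccccc1` differs from compound 1 in one place: benzoyl in place of 4-fluorobenzyl on an oxygen on an unsaturated carbon. For the measured compounds named here, no measured step between compounds tells how such a change moves this assay, so the expectation rests on the tolerated values seen across the group. The step from compound 1 to compound 4 is expected to stay within the scatter, a step that the limit leaves unreadable from compound 1 to compound 4, because compound 2 tolerates 200000 nM. Compound 4 is therefore estimated at 100000 nM, between 30000 nM and 300000 nM.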

Compound 4, half-maximal cytotoxic concentration: > 200000 nM
Compound 4: no number, only a limit; the forecaster's own chance of this, stated with the estimate: 40%; middle value at least 2.0-fold (0.30 log units) from the limit.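

For the compounds shown here, no step from compound 1 to compound 4 can be read, since each of the two carries only a limit and not a number. The compounds shown leave open how far benzoyl in place of 4-fluorobenzyl on an oxygen on an unsaturated carbon moves the result in this assay.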